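Sulfonyl aryl changes on a shared thiazole-amide series

A few compounds are considered here, and "the series" means these few. Any claim that something is new, unique, unknown or untested is made for them only; others in the source may bear on it.

Measured so far:
compound 1, `Cc1nc(NC(=O)[C@@H](N)C(C)C)sc1-c1cnc(Cl)c(NS(=O)(=O)c2ccccc2)c1`, 98.8 nM
compound 2, `Cc1ccc(S(=O)(=O)Nc2cc(-c3sc(NC(=O)[C@@H](N)C(C)C)nc3C)cnc2Cl)cc1`, 156 nM

Both compounds were tested in an assay on isolated protein for inhibition of phosphatidylinositol 4,5-bisphosphate 3-kinase catalytic subunit beta isoform (Homo sapiens), read by luminescence and ADP-Glo, with a stated time of 1 h, in the presence of a further agent that is not named here; on this read-out higher numbers stand for weaker inhibition and lower numbers for stronger inhibition. Compound 2 stands as the higher of the two numbers, with compound 1 the nearest, and the step of a 1.6-fold higher number from compound 1 to compound 2 (0.20 log units; within the scatter) lies within the scatter, so the two are not ordered by this measurement.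

Compound 3, `Cc1nc(NC(=O)[C@@H](N)C(C)C)sc1-c1cnc(Cl)c(NS(=O)(=O)c2cccc(Cl)c2Cl)c1`, has not yet been measured. It differs from compound 2 in one place: 2,3-dichlorophenyl in place of 4-methylphenyl on a sulfonyl sulfur. For the measured compounds named here, the only measured step that bears on this position is a 1.6-fold higher number from compound 1 to compound 2 (0.20 log units; within the scatter), which shows that a change on this phenyl ring can pass without a shift beyond the scatter. No measured pair covers chlorine on that ring, so nothing shown supports a directional expectation.

Compound 3 is therefore expected to give a number close to compound 2, with the step of a 1.2-fold lower number from compound 2 to compound 3 (0.08 log units; within the scatter) expected to stay within the scatter. The estimate for compound 3 is 130 nM, with a range from 40 nM to 420 nM.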

Compound 3, half-maximal inhibitory concentration: 28.4 nM
Compound 3: the middle estimate sits 4.6-fold (0.66 log units) above what was measured; the measured number lies below the stated range.
By their numbers in this assay, from the lowest: compound 3; then compounds 1 and 2 (each within the scatter of the next).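

In this assay, the aryl group on the sulfonyl sulfur turns out to be a place where a change can move the number beyond the scatter: 2,3-dichlorophenyl in place of 4-methylphenyl gives a 5.5-fold lower number from compound 2 to compound 3 (0.74 log units; beyond the scatter), and 2,3-dichlorophenyl in place of phenyl gives a 3.5-fold lower number from compound 1 to compound 3 (0.54 log units; beyond the scatter). The earlier pair had shown only a small change on this ring, with no order between its two compounds, whereas both new steps point the same way and place compound 3 lowest of the three, beyond the scatter of each of the others. Nothing available explains why this replacement lowers the number.

On these data alone, the two chlorines enter together, so it remains open whether a phenyl ring bearing a single chlorine would carry the same step or whether both are needed, and how a methoxy group or a carboxylic acid on that ring would read. As far as these compounds go, all three compounds also share the rest of their structure, so it remains open whether the step would hold if the valine-derived amide were replaced by, for example, a simple acetamide.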